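The source may report more compounds than this note shows. Statements on the series, on what has been measured and on what is new or still open speak of the compounds shown alone.

Compound 1 `COc1ccc(-c2c(S(=O)(=O)c3ccc(F)c(F)c3)cnc3cc(F)ccc23)cc1`, compound 2 `COc1ccc(-c2c(S(=O)(=O)c3cccc(F)c3)cnc3cc(F)ccc23)cc1` and compound 3 `COc1ccc(-c2c(S(=O)(=O)c3ccc(OC)cc3)cnc3cc(F)ccc23)cc1` share one core and were each tested in an ADME assay on microsomes from liver (Homo sapiens) for metabolic stability, tested at 2.5 uM; a higher number here means faster removal of the compound, a lower number slower removal. In this assay compound 1 gives 1.1 mL/min, compound 2 gives 1.89 mL/min and compound 3 gives 1.18 mL/min. Of the three, compound 1 stands at the lowest number, yet a 1.7-fold higher number from compound 1 to compound 2 (0.24 log units; within the scatter) and a 1.1-fold higher number from compound 1 to compound 3 (0.03 log units; within the scatter) are both within the scatter, as is a 1.6-fold lower number from compound 2 to compound 3 (0.20 log units; within the scatter), so the three compounds cannot be told apart on these numbers.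

Compound 4 `COc1cccc(-c2c(S(=O)(=O)c3ccc(F)c(F)c3)cnc3cc(F)ccc23)c1` has not yet been measured in this assay. It differs from compound 1 by 3-methoxyphenyl in place of 4-methoxyphenyl on an aromatic carbon. Among the compounds with values here, the measured steps change the group on the sulfonyl sulfur or swap a fluoro for hydrogen on an aromatic carbon; none of them moves the methoxy group, so no measured step bears directly on this change. Those steps produced nothing beyond the scatter, and the same is expected here: a 1.1-fold higher number from compound 1 to compound 4 (0.04 log units; within the scatter). Compound 4 is thus estimated at 1.2 mL/min, with a range from 0.6 mL/min to 2.4 mL/min.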

Compound 4, intrinsic clearance in a liver preparation (reported as CLH), per the amount of preparation that the assay uses: 1.77 mL/min
Estimate against measurement, compound 4: 1.5-fold (0.17 log units) below; low and high end bracket the measured number.
By their numbers in this assay, from the lowest: compounds 1, 3, 4 and 2 (each within the scatter of the next).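

Swapping 4-methoxyphenyl for 3-methoxyphenyl on this aromatic carbon gives a 1.6-fold higher number from compound 1 to compound 4 (0.21 log units; within the scatter) in this assay. This is the first step shown at this position, as the earlier steps changed only the group on the sulfonyl sulfur or a fluoro on an aromatic carbon, and it shows that moving the methoxy group, with the same atoms joined differently, does not separate the two compounds in this measurement. Nothing shown here offers a measured explanation for the numbers at this position.

The compounds shown leave open whether a different group at this carbon, such as an amine, a carboxylic acid or an unsubstituted phenyl, would give a step beyond the scatter. They also leave open whether the same methoxy move would give a similar step with another group on the sulfonyl sulfur.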